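The compounds below may be only part of what the source reports. "The series", "measured", "known", "first", "only" and "open" are said of these compounds alone.

Measured so far:
compound 1 `C/C(=C\COc1c(Cl)cccc1Cl)CC/C=C(\C)C1CC(=O)C(C)(C)O1` — 50.5 ug/mL
compound 2 `COc1cccc(OC/C=C(\C)CC/C=C(\C)C2CC(=O)C(C)(C)O2)c1` — 33.8 ug/mL

In a functional assay (Homo sapiens) for inhibition (on this read-out lower numbers stand for stronger inhibition and higher numbers for weaker inhibition), compound 2 has the nearest neighbour in compound 1, and the step of a 1.5-fold lower number from compound 1 to compound 2 (0.17 log units; within the scatter) lies within the scatter, so the two compounds cannot be distinguished on this read-out. Compound 3 `C/C(=C\COc1ccccc1)CC/C=C(\C)C1CC(=O)C(C)(C)O1` has not yet been measured. It differs from compound 2 by hydrogen in place of methoxy on an aromatic carbon. Among the measured compounds shown here, no measured step removes a methoxy group from an aromatic ring; the only step at hand, a 1.5-fold lower number from compound 1 to compound 2 (0.17 log units; within the scatter), exchanges one whole aryl group for another and stays within the scatter, so the two aryl groups tried so far give indistinguishable numbers in this assay. On that footing no change beyond the scatter is expected for compound 3. The expected step is a 1.1-fold higher number from compound 2 to compound 3 (0.03 log units; within the scatter). Compound 3 is therefore estimated to give 36 ug/mL in this assay, with a range from 15 ug/mL to 85 ug/mL.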

Compound 3, half-maximal inhibitory concentration: 27.6 ug/mL
Estimate against measurement, compound 3: 1.3-fold (0.12 log units) above; measured number inside the range.
By their numbers in this assay, from the lowest: compounds 3, 2 and 1 (each within the scatter of the next).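

In this assay, the methoxy group meta to a large group can be replaced by hydrogen with a 1.2-fold lower number from compound 2 to compound 3 (0.09 log units; within the scatter) as the result, so the bare phenyl of compound 3 cannot be told apart from the 3-methoxyphenyl of compound 2. Exchanging the 2,6-dichlorophenyl for phenyl gives a 1.8-fold lower number from compound 1 to compound 3 (0.26 log units; within the scatter), so neither the chlorines nor the methoxy group separates from the unsubstituted ring on this read-out. Nothing at hand gives a reason for this flat picture.

As far as these compounds go, whether an amine or a carboxylic acid on the aromatic ring would move the number beyond the scatter remains open. So does the effect of a longer chain between the aryl oxygen and the shared core, since all three compounds keep that chain unchanged.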